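The source may report more compounds than this note shows. Statements on the series, on what has been measured and on what is new or still open speak of the compounds shown alone.

Compound 1 `N#Cc1ccc(OCCCCCn2ccc(=O)[nH]c2=O)cc1`: 100000 nM. Compound 2 `O=c1ccn(CCCCCOc2ccc([N+](=O)[O-])cc2)c(=O)[nH]1`: 20000 nM.

Both were measured in an ADME assay on HEL cells (Homo sapiens) for cytotoxicity, read by microscopy; a lower number here means that less compound is tolerated, a higher number that more compound is tolerated. Compound 2 stands at the lowest of the two numbers; the step of a 5.0-fold lower number from compound 1 to compound 2 (0.70 log units; beyond the scatter) separates it from compound 1. Compound 3 `CC(C)c1ccc(OCCCCCn2ccc(=O)[nH]c2=O)cc1` is not yet measured and differs from compound 2 by isopropyl in place of nitro on an aromatic carbon. For the measured compounds named here, the only measured step at this ring position, a 5.0-fold lower number from compound 1 to compound 2 (0.70 log units; beyond the scatter), compares cyano with nitro and not isopropyl, so it gives no direct guide. A step of a 2.5-fold higher number from compound 2 to compound 3 (0.40 log units; beyond the scatter) is expected, leaning back toward more tolerated compound. Compound 3 is estimated at 50000 nM, within 15000 nM to 100000 nM.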

Compound 3, minimum cytotoxic concentration: 100000 nM
Beside the measured number, compound 3's estimate is 2.0-fold (0.30 log units) below it; the range from low to high includes it.
By their numbers in this assay, from the lowest: compound 2; then compounds 1 and 3 (each within the scatter of the next).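

In this assay, isopropyl in place of nitro gives a 5.0-fold higher number from compound 2 to compound 3 (0.70 log units; beyond the scatter), whereas isopropyl in place of cyano gives no change at the digits printed from compound 1 to compound 3 (within the scatter). At this position, para to a large group, nitro therefore stands apart from both other groups, while the all-carbon isopropyl and the nitrile cannot be told apart. Nothing available accounts for this separation.

Going by these compounds, whether an amine or a carboxylic acid at this position would fall with nitro or with the other two groups remains open. Also open, on these data alone, is how a longer chain would affect these numbers.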